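The source may hold more compounds than are shown below. What is called first, only, known or untested is meant among the compounds shown, and "the series" means these compounds.

Working notes on the urea series built on the shared core of compound 1 `Cc1cc(NC(=O)Nc2ccccc2F)c2ccccc2n1`, compound 2 `Cc1cc(NC(=O)Nc2ccc(O)cc2)c2ccccc2n1` and compound 3 `Cc1cc(NC(=O)Nc2cccnc2)c2ccccc2n1`. In an ADME assay for permeability, using PAMPA, at pH 7.4 (a lower number here means that the compound crosses the layer more slowly, a higher number that the compound crosses the layer faster), compound 1 gives 817 10^-6 cm/s, compound 2 gives 3 10^-6 cm/s and compound 3 gives 63 10^-6 cm/s; compound 2 stands lowest of the three, with a 21-fold higher number from compound 2 to compound 3 (1.32 log units; beyond the scatter) and a 270-fold lower number from compound 1 to compound 2 (2.44 log units; beyond the scatter). Compound 4 `Cc1cc(NC(=O)Nc2ccc(SC(F)(F)F)cc2)c2ccccc2n1` differs from compound 2 in one place: (trifluoromethyl)sulfanyl in place of hydroxy on an aromatic carbon. Going by the values given here, the steps that bear on this change are a 270-fold lower number from compound 1 to compound 2 (2.44 log units; beyond the scatter) and a 21-fold higher number from compound 2 to compound 3 (1.32 log units; beyond the scatter); each pairs the hydroxy compound 2 with a compound lacking the hydroxy and each was large, so a large upward step beyond the scatter is expected, a 170-fold higher number from compound 2 to compound 4 (2.22 log units; beyond the scatter). For compound 4 the number expected in this assay is 500 10^-6 cm/s, with a range of 120 10^-6 cm/s to 1500 10^-6 cm/s.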

Compound 4, apparent permeability: 206 10^-6 cm/s
Compound 4: middle estimate off by 2.4-fold (0.39 log units), on the high side; low and high end bracket the measured number.
By their numbers in this assay, from the lowest: compound 2; then compound 3; then compound 4; then compound 1.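

Going by these compounds alone, compound 4 keeps the phenyl ring of compound 2 and changes only the group on the aromatic carbon, whereas the earlier steps replaced the whole aryl group. That single exchange of hydroxy for (trifluoromethyl)sulfanyl gives a 69-fold higher number from compound 2 to compound 4 (1.84 log units; beyond the scatter) in this assay, so a change at this carbon alone is enough for a large rise. No measurement on hand accounts for the step. Open, as far as these compounds go, is how much of it follows the loss of hydroxy and how much the entering group. A methoxy group or a chlorine atom on the same carbon could help separate the two.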